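The source may hold more compounds than are shown below. What is called first, only, known or untested is meant among the compounds shown, and "the series" means these compounds.

Measured so far:
compound 1 `O=C1C=C(Nc2ccc(I)cc2)C(=O)c2c1nc1n2[C@H]2OC[C@@H](O)[C@H]2OC1`: 4070 nM
compound 2 `Cc1ccc(NC2=CC(=O)c3c(nc4n3[C@H]3OC[C@@H](O)[C@H]3OC4)C2=O)cc1C`: 4320 nM

In a functional assay on HeLa cells (Homo sapiens) for inhibition, read by sulforhodamine B assay (on this read-out higher numbers stand for weaker inhibition and lower numbers for stronger inhibition), compound 1 gives 4070 nM and compound 2 gives 4320 nM. Compound 2 holds the higher of the two numbers, yet its gap to compound 1 lies within the scatter, so the two cannot be told apart. Compound 3 `O=C1C(Nc2ccccc2)=CC(=O)c2c1nc1n2[C@H]2OC[C@@H](O)[C@H]2OC1` awaits measurement in this assay; against compound 2 it shows (phenyl in place of 3,4-dimethylphenyl on an amine nitrogen). For the measured compounds named here, no measured pair reports this change, so the expected step is a 1.2-fold higher number from compound 2 to compound 3 (0.06 log units; within the scatter), none beyond the scatter. Compound 3 is estimated at 5000 nM, between 2000 nM and 12500 nM.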

Compound 3, half-maximal inhibitory concentration: > 8000 nM
Compound 3 was reported as a limit; the forecaster's own chance of this, stated with the estimate: 10%; middle value at least 1.6-fold (0.20 log units) away from the limit.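

In this assay compound 3 is reported only as a limit, > 8000 nM. On the amine nitrogen, phenyl in place of 3,4-dimethylphenyl gives an at least 1.8-fold higher number from compound 2 to compound 3 (0.26 log units; that floor lies within the scatter), the first step read at this place; it leaves open a larger change, but its floor alone establishes none beyond the scatter. The size of this step is bounded on one side only: the limit of > 8000 nM in this assay, at which 1 of the 3 values shown sits.

From the compounds shown here alone, the true value of compound 3 remains open. So does how a single methyl on the phenyl ring, or a carboxylic acid there, would read.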